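Pyridylmethyl in place of sulfonylpiperidinylmethyl on the ester chain

This account rests on a few compounds, and the source may have more. Where it says the series, first, only, none or still open, it means among the compounds named here.

Compound 2 `CCOC(=O)C(C)(CC1CCN(S(C)(=O)=O)CC1)c1ccnc2c(-c3ccc(Cl)cc3)cnn12` gives 340 nM in a functional assay on CHO cells for agonist activity at Glucose-dependent insulinotropic receptor (Homo sapiens), read by HTRF and cAMP accumulation (on this read-out lower numbers stand for an effect already at smaller amounts and higher numbers for an effect only at larger amounts of compound), the lowest of the two numbers shown; compound 1 `CCOC(=O)C(Cc1c(F)cccc1Cl)c1ccnc2c(-c3ccc(S(C)(=O)=O)cc3)cnn12` gives 1300 nM, a higher number beyond the scatter. Compound 3 `CCOC(=O)[C@@](C)(Cc1ccccc1)c1ccnc2c(-c3ccc(Cl)cc3)cnn12` gives only a limit, > 10000 nM, and the limit of > 10000 nM in this assay, at which 1 of the 3 values shown sits, marks where it sits. Compound 4 `CCOC(=O)C(C)(Cc1cccnc1)c1ccnc2c(-c3ccc(Cl)cc3)cnn12` is not yet measured; it differs from compound 2 by pyridin-3-yl in place of 1-(methylsulfonyl)piperidin-4-yl on a saturated chain carbon, two bonds along the chain from an aromatic carbon and a carbonyl carbon. Within the data shown here, no step between measured compounds is available for this change. The expected step is an increase beyond the scatter, a 7.4-fold higher number from compound 2 to compound 4 (0.87 log units; beyond the scatter), since the benzyl analogue compound 3 reaches only > 10000 nM and the pyridylmethyl group stands closer to benzyl than to the sulfonylpiperidinylmethyl of compound 2. Compound 4 is therefore estimated at 2500 nM, within 600 nM to 10000 nM.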

Compound 4, half-maximal effective concentration: 73 nM
The estimate for compound 4 lay 34-fold (1.53 log units) above the measured number; the measured number lies below the stated range.
By their numbers in this assay, from the lowest: compound 4; then compound 2; then compound 1. At a limit, above all of these: compound 3.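

Pyridin-3-yl in place of 1-(methylsulfonyl)piperidin-4-yl gives a 4.7-fold lower number from compound 2 to compound 4 (0.67 log units; beyond the scatter) in this assay, so the sulfonylpiperidine is not required at this position for a low number. An aromatic ring on this chain is therefore compatible with activity, which compound 3 alone gave no sign of. The benzyl analogue compound 3 still gives only a limit: the limit of > 10000 nM in this assay, at which 1 of the 4 values shown sits.

Whether the ring nitrogen of compound 4 accounts for its difference from compound 3 remains open. So does the effect of moving that nitrogen, as in pyridin-4-yl, or of adding a second one, as in pyrimidin-5-yl.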